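A few compounds are considered here, and "the series" means these few. Any claim that something is new, unique, unknown or untested is made for them only; others in the source may bear on it.

Measured in an ADME assay on liver for metabolic stability, with Liver microsome (Homo sapiens) as the target, read by LC-MS, using microsomes; on this read-out higher numbers stand for fast clearance and lower numbers for slow clearance:
Compound 1 `CC(C)(C)OC[C@@H](O)C(=O)N1[C@H](C(=O)NCc2cc(Cl)ccc2-n2cnnn2)C[C@@H]2C[C@@H]21`: 21 mL.min-1.g-1
Compound 2 `O=C(NCc1cc(Cl)ccc1-n1cnnn1)[C@@H]1CC=NN1C(=O)[C@H](O)c1ccccc1F`: 16 mL.min-1.g-1
Compound 3 `CC1(C[C@@H](O)C(=O)N2C[C@H]3C[C@H]3[C@H]2C(=O)NCc2cc(Cl)ccc2-n2cnnn2)CC1`: 12 mL.min-1.g-1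

Compound 2, at 16 mL.min-1.g-1, lies within the scatter of both other compounds. Compound 4 `CCCC[C@@H](O)C(=O)N1N=CC[C@H]1C(=O)NCc1cc(Cl)ccc1-n1cnnn1` differs from it in one place: butyl in place of 2-fluorophenyl on a saturated chain carbon bound to a carbonyl carbon and an oxygen on a saturated carbon. Within the data shown here, no measured pair isolates this change. Compound 1, with 21 mL.min-1.g-1, and compound 3, with 12 mL.min-1.g-1, also lack an aromatic ring on that carbon, though on other cores. The expected step in this assay, a 1.4-fold higher number from compound 2 to compound 4 (0.14 log units; within the scatter), is small and upward, no larger than the scatter. For compound 4 the estimated value is 22 mL.min-1.g-1, with an expected range of 11 mL.min-1.g-1 to 45 mL.min-1.g-1.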

Compound 4, intrinsic clearance in microsomes: < 12 mL.min-1.g-1
Compound 4 was reported as a limit; the forecaster's own chance of this, stated with the estimate: 3%; middle value at least 1.8-fold (0.26 log units) from the limit.
By their numbers in this assay, from the lowest: compounds 3, 2 and 1 (each within the scatter of the next).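

On the shared core, butyl in place of 2-fluorophenyl gives an at least 1.3-fold lower number from compound 2 to compound 4 (0.12 log units; that floor lies within the scatter) in this assay, a floor that says nothing of the full size of the step. Among these compounds, at this position, the aromatic ring gives way to an open chain with no rise in the number, which no earlier pair could show on one core. The value of compound 4 is a limit and not a number: the limit of < 12 mL.min-1.g-1 in this assay, at which 1 of the 4 values shown sits.

From the compounds shown here alone, whether the fluorine, the ring or the chain itself decides this stays open. A plain phenyl or a propyl chain on this carbon could separate these.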